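The source may hold more compounds than are shown below. What is called first, only, known or untested is meant among the compounds shown, and "the series" means these compounds.

Series notes. Within the data shown here, in an assay on CHO cells for displacement of a labelled ligand from Orexin/Hypocretin receptor type 1 (Homo sapiens) (on this read-out higher numbers stand for weaker inhibition and lower numbers for stronger inhibition), compound 3 `Cn1c(SCC(=O)N2CCC[C@H]2C(=O)Nc2ccccc2-c2ccccc2)nc2ccccc21` gives 3 nM, the lowest number among the three compounds measured so far. Compound 1 `Cn1c(SCC(=O)N2CCC[C@H]2C(=O)Nc2ccccc2-n2cccc2)nc2ccccc21` gives 9 nM in this assay, and compound 2 `O=C(Nc1ccccc1-c1ccccc1)[C@@H]1CCCN1C(=O)CSc1nc2ccccc2[nH]1` gives 10 nM in this assay. The two measured steps leading into compound 3 are a 3.0-fold lower number from compound 1 to compound 3 (0.48 log units; beyond the scatter) and a 3.3-fold lower number from compound 2 to compound 3 (0.52 log units; beyond the scatter); both are modest, and both lie beyond the scatter.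

Compound 4 `Cn1c(CCC(=O)N2CCC[C@H]2C(=O)Nc2ccccc2-c2ccccc2)nc2ccccc21` has not yet been measured in this assay. It differs from compound 3 in one place: (1-methyl-1H-benzimidazol-2-yl)methyl in place of (1-methyl-1H-benzimidazol-2-yl)sulfanyl on a saturated chain carbon bound to a carbonyl carbon. Neither measured step touches this part of the molecule; one concerns the group on an aromatic carbon, the other the group on an aromatic nitrogen. Among the measured compounds shown here, there is thus no measured step that bears on the change from compound 3 to compound 4, and the expectation rests on the rest of the molecule being unchanged. With that in mind the step is expected to be about a 2.0-fold higher number from compound 3 to compound 4 (0.30 log units; within the scatter) in this assay, not beyond the scatter in either direction. Compound 4 is therefore estimated at 6 nM in this assay, with a range from 2 nM to 25 nM.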

Compound 4, inhibition constant in the Orexin/Hypocretin receptor type 1 assay: 15 nM
Estimate against measurement, compound 4: 2.5-fold (0.40 log units) below, and the stated range covers the measured number.
By their numbers in the Orexin/Hypocretin receptor type 1 assay, from the lowest: compound 3; then compounds 1, 2 and 4 (each within the scatter of the next).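

Among these compounds, the saturated chain carbon bound to a carbonyl carbon is not a silent position: in the Orexin/Hypocretin receptor type 1 assay, (1-methyl-1H-benzimidazol-2-yl)methyl in place of (1-methyl-1H-benzimidazol-2-yl)sulfanyl gives a 5.0-fold higher number from compound 3 to compound 4 (0.70 log units; beyond the scatter), the first measured step at this place. With (1H-benzimidazol-2-yl)sulfanyl as the group that leaves, the same entering group gives a 1.5-fold higher number from compound 2 to compound 4 (0.18 log units; within the scatter), so that step shows no separation. In a physicochemical assay for lipophilicity (a lower number here means a more polar compound, a higher number a more lipophilic compound), compound 3 gives 3.4 and compound 4 gives 2.6. In the physicochemical assay, the weaker inhibition of the step from the sulfanyl to the methyl link comes together with a more polar compound: the measured partition coefficient of compound 3, 3.4, and of compound 4, 2.6, a number 0.80 log units lower (beyond the scatter)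

Going by these compounds, with a single pair read in both assays, it remains open whether the weaker inhibition follows the lipophilicity or the link itself. On these data alone, how an ether oxygen, an amine nitrogen or a longer chain would compare at this place also remains open.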